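Cytotoxicity of aryl thiocarbamates: from chloro to methoxy

A few compounds are considered here, and "the series" means these few. Any claim that something is new, unique, unknown or untested is made for them only; others in the source may bear on it.

In an ADME assay on MT4 cells (Homo sapiens) for cytotoxicity, read by MTT assay (on this read-out higher numbers stand for lower toxicity in this test and lower numbers for higher toxicity in this test), the measured compounds gave:
- compound 1 `S=C(Nc1ccccc1)OCCc1ccccn1`: > 100000 nM, a limit of the test rather than a number
- compound 2 `FC(F)(F)c1ccc(NC(=S)OCCc2ccccn2)cc1`: 50000 nM
- compound 3 `S=C(Nc1ccc(Cl)cc1)OCCc1ccccn1`: 52000 nM

Compound 3 holds the higher of the two numbers obtained, yet compound 2 sits at a distance within the scatter, so the two cannot be told apart. Compound 1 is known only as a limit (the limit of > 100000 nM in this assay, at which 1 of the 3 values shown sits). The unmeasured compound 4 `COc1ccc(NC(=S)OCCc2ccccn2)cc1` differs from compound 3 by methoxy in place of chloro on an aromatic carbon. Among the measured compounds shown here, two measured steps touch the same aromatic carbon: an at least 1.9-fold lower number from compound 1 to compound 3 (0.28 log units; that floor lies within the scatter) and a 1.0-fold higher number from compound 2 to compound 3 (0.02 log units; within the scatter). The first rests on a limit and reaches only the scatter floor; the second is flat. The step of an at least 2.0-fold lower number from compound 1 to compound 2 (0.30 log units; that floor lies within the scatter) likewise stays at the floor. For the measured compounds named here, no measured step carries a methoxy group, so the expectation for compound 4 in this assay rests on the flat exchange seen between compound 2 and compound 3 and on the limit of compound 1. Compound 4 is therefore expected to give 70000 nM, between 30000 nM and 150000 nM, an expected step of a 1.3-fold higher number from compound 3 to compound 4 (0.13 log units; within the scatter), not beyond the scatter, with a real chance that only a limit is reported.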

Compound 4, half-maximal cytotoxic concentration: 48000 nM
Estimate against measurement, compound 4: 1.5-fold (0.16 log units) above, within the range that was stated.
By their numbers in this assay, from the lowest: compounds 4, 2 and 3 (each within the scatter of the next). At a limit, above all of these: compound 1.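

In this assay, methoxy, which brings a hydrogen-bond acceptor that chloro lacks, leaves the number at this aromatic carbon within the scatter: a 1.1-fold lower number from compound 3 to compound 4 (0.03 log units; within the scatter), and likewise a 1.0-fold lower number from compound 2 to compound 4 (0.02 log units; within the scatter). Methoxy, chloro and trifluoromethyl at this place thus cannot be told apart, while the step of an at least 2.0-fold lower number from compound 1 to compound 4 (0.31 log units; beyond the scatter) is the first from hydrogen to pass the scatter, and it does so only as a floor. That floor rests on compound 1, whose value is a limit: the limit of > 100000 nM in this assay, at which 1 of the 4 values shown sits.

From the compounds shown here alone, whether an amine or a carboxylic acid at this place would stand apart from these three groups remains open, as does the outcome of a longer chain elsewhere on the shared core. Going by these compounds, the full size of the change from hydrogen stays open as well.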